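Swapping the Aryl Ring on a Shared Hydrazone Core

This account rests on a few compounds, and the source may have more. Where it says the series, first, only, none or still open, it means among the compounds named here.

Two compounds share one core and differ only in the aromatic ring hung on a carbon with a double bond to nitrogen. Compound 1 `Cc1ccc(/C=N/Nc2ncc3c(n2)n(C2CCCC2)c(=O)c(=O)n3C)cc1C` carries a 3,4-dimethylphenyl ring, and in a functional assay on PC-3 cells (Homo sapiens) for antiproliferative activity, read by MTT assay (a higher number here means a weaker inhibitor, a lower number a stronger inhibitor), compound 1 gives 39000 nM. Within the data shown here, compound 2 `CSc1ccc(/C=N/Nc2ncc3c(n2)n(C2CCCC2)c(=O)c(=O)n3C)cc1` carries a 4-(methylsulfanyl)phenyl ring instead, and in this assay compound 2 gives 21000 nM, the lowest of the two numbers measured so far; the step of a 1.9-fold lower number from compound 1 to compound 2 (0.27 log units; within the scatter) is the only one known, and it stays within the scatter. Compound 3 `Cn1c(=O)c(=O)n(C2CCCC2)c2nc(N/N=C/c3ccc(F)cc3F)ncc21` has not yet been measured. Its change from compound 2 is 2,4-difluorophenyl in place of 4-(methylsulfanyl)phenyl on a carbon with a double bond to nitrogen. Among the measured compounds shown here, the one step that bears on this exchange, a 1.9-fold lower number from compound 1 to compound 2 (0.27 log units; within the scatter), shows that replacing one ring by another at this carbon has so far moved the number by no more than the scatter. The step expected in this assay is therefore a 1.2-fold higher number from compound 2 to compound 3 (0.08 log units; within the scatter), with no clear direction. Compound 3 is accordingly estimated at 25000 nM in this assay, within a range from 8000 nM to 70000 nM.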

Compound 3, half-maximal inhibitory concentration: 13200 nM
Compound 3: the middle estimate sits 1.9-fold (0.28 log units) above what was measured; the range from low to high includes it.
By their numbers in this assay, from the lowest: compounds 3, 2 and 1 (each within the scatter of the next, the first and the last beyond it).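

The new value shows that the ring on this carbon can shift the number measurably, though only modestly. Among these compounds, the exchange of 4-(methylsulfanyl)phenyl for 2,4-difluorophenyl gives a 1.6-fold lower number from compound 2 to compound 3 (0.20 log units; within the scatter) in this assay and so stays as unresolved as the first step, but the exchange of 3,4-dimethylphenyl for 2,4-difluorophenyl gives a 3.0-fold lower number from compound 1 to compound 3 (0.47 log units; beyond the scatter) and is the first step at this position to pass beyond the scatter. Compound 2 remains within the scatter of both neighbours, so the three rings do not form three separate levels, and only the two ends of the series can be told apart; no measurement offered here explains why these two rings differ.

From the compounds shown here alone, all three compounds carry a substituted phenyl ring with only methyl, methylsulfanyl or fluoro groups on it, so it remains open whether an amine, a carboxylic acid or a longer chain on that ring would move the number further, and in which direction. Going by these compounds, the shared core is also the same throughout, so whether the modest step seen here would hold on a different core remains unknown.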